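The source may hold more compounds than are shown below. What is called first, only, known or untested is meant among the compounds shown, and "the series" means these compounds.

Working notes on the series. The shared core carries two amino groups and a phenyl ring; compound 1 `Nc1cc(N)c2nc(-c3ccccc3)c(NCc3ccc(Cl)c(Cl)c3)nc2c1` and compound 2 `COc1ccc(CNc2nc3cc(N)cc(N)c3nc2-c2ccccc2)cc1OC` differ only in the aryl group on the saturated chain carbon bound to the ring nitrogen. In a functional assay on NCI/ADR-RES cells (Homo sapiens) for inhibition, read by sulforhodamine B assay, with a stated time of 48 h (a lower number here means a stronger inhibitor of growth, a higher number a weaker inhibitor of growth), compound 1 gives 17400 nM, and compound 2 gives 17800 nM. The step of a 1.0-fold higher number from compound 1 to compound 2 (0.01 log units; within the scatter) shows that this aryl swap left the number essentially unchanged, so compound 2 and compound 1 sit within the scatter of each other and no order between them can be read.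

Compound 3 `COc1cc(CNc2nc3cc(N)cc(N)c3nc2-c2ccccc2)cc(OC)c1OC` carries the change (methoxy in place of hydrogen on an aromatic carbon). Going by the values given here, no measured step adds a group to this aryl ring; the only step at hand, the aryl exchange from compound 1 to compound 2, was flat. Following that precedent, the step of no change at the digits printed from compound 2 to compound 3 (within the scatter) is expected to stay within the scatter. Compound 3 is therefore estimated at 17800 nM, within 8000 nM to 40000 nM, in this assay.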

Compound 3, concentration for 50% growth inhibition: 10200 nM
Estimate against measurement, compound 3: 1.7-fold (0.24 log units) above; low and high end bracket the measured number.
By their numbers in this assay, from the lowest: compounds 3, 1 and 2 (each within the scatter of the next).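

A methoxy group in place of hydrogen on the aromatic carbon ortho to a methoxy group and meta to a large group gives a 1.7-fold lower number from compound 2 to compound 3 (0.24 log units; within the scatter) in this assay, so no gain or loss can be read from this addition. Where the earlier step exchanged one substituted aryl group for another, this one adds a group to the aryl ring, and this position accepts that addition with the number still within the scatter. No measurement on hand bears on this result.

From the compounds shown here alone, whether another group on this aromatic carbon, such as an amine or a carboxylic acid, would move the number beyond the scatter remains open. Also open, going by these compounds, is whether a longer chain in place of the single saturated carbon leading to the aryl ring would do so.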